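Removing one fluorine from a trimethoxyphenyl hydrazone

The source may report more compounds than this note shows. Statements on the series, on what has been measured and on what is new or still open speak of the compounds shown alone.

Compound 1 `COc1cc(C(=O)N/N=C/c2ccc(F)c(F)c2)cc(OC)c1OC` is the strongest of the three compounds measured here: in a functional assay on PC-3 cells (Homo sapiens) for antiproliferative activity, read by MTT assay, tested at 1 uM (on this read-out lower numbers stand for a weaker effect and higher numbers for a stronger effect at the one concentration tested), compound 1 gives 35.1%. The other two carry a different core. Compound 2 `COc1cc(C2=NN(C(C)=O)C(c3ccccc3C(F)(F)F)O2)cc(OC)c1OC` gives -11% in this assay, and compound 3 `COc1cc(C2=NN(C(C)=O)C(c3ccc(F)cc3)O2)cc(OC)c1OC` gives 0%, so both sit far below compound 1, beyond the scatter.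

Compound 4 `COc1cc(C(=O)N/N=C/c2ccc(F)cc2)cc(OC)c1OC` is compound 1 with hydrogen in place of fluoro on an aromatic carbon. Within the data shown here, the only measured step, a number 11 percentage points higher from compound 2 to compound 3 (beyond the scatter), swaps 4-fluorophenyl for 2-(trifluoromethyl)phenyl on a saturated ring carbon of a different core, which is not the change made here; it shows only that a modest shift can follow a change of the fluorinated phenyl group. Among the measured compounds shown here, no measured pair removes a single fluoro from an aromatic carbon on the core of compound 1. With so little to go on, the expected step in this assay is small, most likely within the scatter. Fluoro leaves and nothing but hydrogen enters, and the expectation leans slightly toward weaker. Compound 4 is therefore expected to give 30%, between 10% and 50%, a change of a number 5.1 percentage points lower from compound 1 to compound 4 (within the scatter) that is estimated rather than measured.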

Compound 4, a percentage reported as inhibition, at one concentration (the size of the read-out at that concentration, not a potency): 76%
Compound 4: the middle estimate sits 46 percentage points below what was measured, outside the stated range (above it).
By their numbers in this assay, from the lowest: compound 2; then compound 3; then compound 1; then compound 4.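

In this assay, the change from 3,4-difluorophenyl to 4-fluorophenyl gives a number 40.9 percentage points higher from compound 1 to compound 4 (beyond the scatter) and so shows that this aromatic carbon, ortho to a fluoro group and meta to a large group, is far from a silent position on the core of compound 1. Among these compounds, the earlier compounds could not show this, since none of their pairs changes a single atom on this core, and their one measured step concerns a different core and a swap of whole phenyl groups. Here a single fluorine gives way to hydrogen, and the antiproliferative effect at the one tested concentration rises, though no measurement at hand explains this rise.

The compounds shown leave open whether another small group at this same carbon, such as chloro or an amine, would keep the higher reading or lose it. They also leave open what happens on the same core when the remaining fluoro gives way to hydrogen as well, leaving a plain phenyl ring, and whether the step would hold up across a range of concentrations.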